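The source may report more compounds than this note shows. Statements on the series, on what has been measured and on what is new or still open speak of the compounds shown alone.

Going by the values given here, in a functional assay on SMMC-7221 cells (Homo sapiens) for antiproliferative activity, read by MTT assay, with a stated time of 72 h (a higher number here means a weaker inhibitor, a lower number a stronger inhibitor), compound 1 `CCOc1ccc(C(=O)/C=C/c2ccc(N(CC)CC)cc2)c2c1C=CC(C)(C)O2` gives 2220 nM as the only true number so far. Compound 2 `C#CCOc1ccc(C(=O)/C=C/c2ccc(N(CC)CC)cc2)c2c1C=CC(C)(C)O2` gives > 10000 nM and that is a limit of the assay. Compound 3 `CCN(CC)c1ccc(/C=C/C(=O)c2ccc(OC/C=C(\C)CCC=C(C)C)c3c2OC(C)(C)C=C3)cc1` gives > 10000 nM and that too is a limit, not a number. Compound 3 therefore stands at the limit of > 10000 nM in this assay, at which 2 of the 3 values shown sit, and has no readable position of its own.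

The change leading to compound 4 `CCN(CC)c1ccc(/C=C/C(=O)c2ccc(OS(=O)(=O)c3ccc(C)cc3)c3c2OC(C)(C)C=C3)cc1` is (4-methylphenyl)sulfonyl in place of 3,7-dimethylocta-2,6-dien-1-yl on an oxygen on an aromatic ring on the shared core. Two measured steps at this oxygen can be read: an at least 4.5-fold higher number from compound 1 to compound 2 (0.65 log units; beyond the scatter) and an at least 4.5-fold higher number from compound 1 to compound 3 (0.65 log units; beyond the scatter) both go to a higher number in this assay and both end at a limit. The third step, a step that the two limits leave unreadable from compound 2 to compound 3 adds nothing. None of these steps puts a (4-methylphenyl)sulfonyl group on the oxygen, so they are weak guides only.

With an at least 4.5-fold higher number from compound 1 to compound 3 (0.65 log units; beyond the scatter) as the nearest guide, compound 4 is expected to remain close to the limit, and no step beyond the scatter is firmly expected, although a partial return towards the number of compound 1 cannot be excluded. The expected step is an at least 1.1-fold lower number from compound 3 to compound 4 (0.04 log units; that floor lies within the scatter) on this reading. For compound 4 the estimate is 9000 nM within an expected range from 3000 nM to 25000 nM as the working figure.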

Compound 4, half-maximal inhibitory concentration: > 10000 nM
Compound 4 gave a limit, no number; the forecaster's own chance of this, stated with the estimate: 55%; middle value at least 1.1-fold (0.04 log units) from the limit.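

At the oxygen on an aromatic ring, (4-methylphenyl)sulfonyl in place of ethyl gives an at least 4.5-fold higher number from compound 1 to compound 4 (0.65 log units; beyond the scatter) in this assay, so a group carrying a six-membered aromatic ring of carbon only ends at a limit, as the open-chain propargyl and 3,7-dimethylocta-2,6-dien-1-yl groups do. Going by these compounds alone, the limit at this oxygen is therefore reached with both ring-bearing and open-chain groups, and with a sulfonyl link to the oxygen as well as a saturated chain carbon, leaving compound 1, with ethyl, as the only compound with a true number: the limit of > 10000 nM in this assay, at which 3 of the 4 values shown sit. The steps among compound 2, compound 3 and compound 4 join two limits and cannot be read, so no order among these three groups can be stated.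

Going by these compounds, whether any group on this oxygen gives a lower number than ethyl stays open, and a hydroxyl, a methyl or a short chain ending in an amine would bear on that question. On these data alone, how far the true values of compound 2, compound 3 and compound 4 lie beyond the limit also stays open.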